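Swapping an ethyl for a methoxy on the aniline ring

The source may report more compounds than this note shows. Statements on the series, on what has been measured and on what is new or still open speak of the compounds shown alone.

Of the compounds shown here, three sharing one core have been measured so far. In a functional assay for inhibition, with Homo sapiens as the target (a lower number here means a stronger inhibitor, a higher number a weaker inhibitor), compound 1 `COc1cccc(Nc2nccc(-c3ccsc3)n2)c1` gives 1800 nM, compound 2 `COc1cccc(Nc2nccc(-c3ccc(C)o3)n2)c1` gives 1500 nM, and compound 3 `CCc1cccc(Nc2nccc(-c3ccccn3)n2)c1` gives 1400 nM. Going by the values given here, the one step between compounds differing in a single place is a 1.2-fold lower number from compound 1 to compound 2 (0.08 log units; within the scatter), a change at the other end of the molecule. Compound 3 holds the lowest of the three numbers, yet both compound 2 and compound 1 sit within the scatter of it, so no order among them can be claimed.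

Compound 4 `COc1cccc(Nc2nccc(-c3ccccn3)n2)c1` is not yet measured. It differs from compound 3 as follows: methoxy in place of ethyl on an aromatic carbon. Among the compounds with values here, no measured step touches this position; the only known step concerns a different ring. Compound 2 and compound 1, which carry the methoxy group entering here, give numbers close to that of compound 3, which points to no change beyond the scatter in this assay.

The author therefore expects a 1.1-fold higher number from compound 3 to compound 4 (0.03 log units; within the scatter) for this change. Compound 4 is estimated at 1500 nM, with a range from 700 nM to 3200 nM.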

Compound 4, half-maximal inhibitory concentration: 200 nM
For compound 4 the middle estimate is 7.5-fold (0.88 log units) above the measured one; the measured number lies below the stated range.
By their numbers in this assay, from the lowest: compound 4; then compounds 3, 2 and 1 (each within the scatter of the next).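

With pyridin-2-yl held fixed, methoxy in place of ethyl on this aromatic carbon, meta to a large group, brings a 7.0-fold lower number from compound 3 to compound 4 (0.85 log units; beyond the scatter) in this assay and so shows that this position, untouched by any earlier step, bears on the result. With methoxy held fixed, the other end of the molecule also proves to matter: pyridin-2-yl in place of 5-methylfuran-2-yl brings a 7.5-fold lower number from compound 2 to compound 4 (0.88 log units; beyond the scatter) and pyridin-2-yl in place of thiophen-3-yl brings a 9.0-fold lower number from compound 1 to compound 4 (0.95 log units; beyond the scatter) so that, among these four, only compound 4 carries both groups and only compound 4 stands apart. Nothing at hand explains why this swap acts as it does.

The compounds shown leave open whether methoxy would outdo ethyl with thiophen-3-yl or 5-methylfuran-2-yl at the other end. They also leave open how a hydroxyl, an amine or a longer ether chain would fare on this carbon.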